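The source may report more compounds than this note shows. Statements on the series, on what has been measured and on what is new or still open speak of the compounds shown alone.

Measured in a functional assay on the whole organism with Mus musculus as the target; a higher number here means that more compound is needed for the effect, a lower number that less compound is needed:
compound 1 `Cc1c(C)c2c(c(C)c1N)CC(C)(C)O2` gives 7.8 mg/kg
compound 2 `Cc1c(C)c2c(c(N(C)C)c1N)CC(C)(C)O2` gives 22.3 mg/kg
compound 3 `Cc1c(N)c(C)c2c(c1CC(C)C)OC(C)(C)C2` gives 13.3 mg/kg

One measured step stays within the scatter (a 1.7-fold higher number from compound 1 to compound 3 (0.23 log units; within the scatter)) and one goes beyond it (a 2.9-fold higher number from compound 1 to compound 2 (0.46 log units; beyond the scatter)), which leaves compound 1 at the low end of the numbers, together with compound 3. Compound 4 `CC(=O)Nc1c(C)c(C)c2c(c1C)CC(C)(C)O2` turns amino to acetamido (acetyl in place of hydrogen on a nitrogen on an aromatic ring). Within the data shown here, neither measured step falls on that nitrogen, so both guide size only, and the data show no direct precedent for the direction. A modest move to a higher number is tentatively expected, comparable to the larger measured step (a 2.9-fold higher number from compound 1 to compound 2 (0.46 log units; beyond the scatter)). The expected change is thus modest (a 2.6-fold higher number from compound 1 to compound 4 (0.41 log units; beyond the scatter)). Compound 4 is therefore estimated at 20 mg/kg with an expected range from 7 mg/kg to 55 mg/kg in this assay.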

Compound 4, dose for 50% inhibition: > 100 mg/kg
Compound 4 was reported as a limit; the forecaster's own chance of this, stated with the estimate: 10%; at least 5.0-fold (0.69 log units) between middle value and limit.
By their numbers in this assay, from the lowest: compounds 1, 3 and 2 (each within the scatter of the next, the first and the last beyond it). At a limit, above all of these: compound 4.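

In this assay compound 4 is reported only as a limit, > 100 mg/kg. Acetyl in place of hydrogen on this nitrogen gives a large step, an at least 12-fold higher number from compound 1 to compound 4 (1.10 log units; beyond the scatter), so the first change shown at this nitrogen is also the one with the greatest effect on the number. The two earlier steps, made elsewhere on the shared core, gave no sign of this sensitivity. Going by these compounds, it remains open whether the effect is specific to acetyl or extends to other groups on this nitrogen, such as methyl or methanesulfonyl.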